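A few compounds are considered here, and "the series" means these few. Any claim that something is new, unique, unknown or untested is made for them only; others in the source may bear on it.

Measured so far in an ADME assay on microsomes from liver (Homo sapiens) for metabolic stability, read by LC-MS, using NADPH, with stated times of 5 min and 30 min, tested at 1 uM; a lower number here means slower removal, a higher number faster removal of the compound:
- compound 1 `Cc1nccn1-c1cnc(NCc2c(F)ccc3c2CCO3)c2cn[nH]c(=O)c12` gives 8 mL.min-1.g-1
- compound 2 `CC(=O)N1CCC(c2cnc(NCc3c(F)ccc4c3CCO4)c3cn[nH]c(=O)c23)CC1` gives 207 mL.min-1.g-1
- compound 3 `Cc1nc(CN(C)C)ccc1-c1cnc(NCc2c(F)ccc3c2CCO3)c2cn[nH]c(=O)c12` gives 13 mL.min-1.g-1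

Compound 3 (13 mL.min-1.g-1) sits with compound 1 at the low end of these three numbers, and the two lie within the scatter of each other, as a 1.6-fold higher number from compound 1 to compound 3 (0.21 log units; within the scatter) shows. Compound 2 stands well apart, with a 16-fold lower number from compound 2 to compound 3 (1.20 log units; beyond the scatter) as the measured gap.

The next step leads to compound 4 `Cc1nn(C)cc1-c1cnc(NCc2c(F)ccc3c2CCO3)c2cn[nH]c(=O)c12` and is 1,3-dimethyl-1H-pyrazol-4-yl in place of 6-((dimethylamino)methyl)-2-methylpyridin-3-yl on an aromatic carbon in all: 1,3-dimethyl-1H-pyrazol-4-yl in place of 6-((dimethylamino)methyl)-2-methylpyridin-3-yl on an aromatic carbon.

Among the compounds with values here, two measured steps bear most directly on it. Replacing the aromatic ring of compound 1 with the 1-acetylpiperidin-4-yl group gave the large 26-fold higher number from compound 1 to compound 2 (1.41 log units; beyond the scatter) (no aromatic ring at that carbon). Exchanging one aromatic ring for another gave only a 1.6-fold higher number from compound 1 to compound 3 (0.21 log units; within the scatter) (within the scatter). Compound 4 keeps an aromatic ring at this carbon, so it is expected to follow compound 1 and compound 3 rather than compound 2. Within the data shown here, this rests on only three compounds, and no pyrazole has been measured.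

The expected change is a 1.1-fold lower number from compound 3 to compound 4 (0.03 log units; within the scatter) (none beyond the scatter). In this assay the estimated value for compound 4 is 12 mL.min-1.g-1 (expected range 5 mL.min-1.g-1 to 32 mL.min-1.g-1).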

Compound 4, intrinsic clearance in microsomes: 27 mL.min-1.g-1
For compound 4 the middle estimate is 2.3-fold (0.35 log units) below the measured one; the range from low to high includes it.
By their numbers in this assay, from the lowest: compounds 1 and 3 (each within the scatter of the next); then compound 4; then compound 2.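

In this assay the aromatic groups at this carbon no longer all read alike: the five-membered 1,3-dimethyl-1H-pyrazol-4-yl gives a 2.1-fold higher number from compound 3 to compound 4 (0.32 log units; beyond the scatter) and also a 3.4-fold higher number from compound 1 to compound 4 (0.53 log units; beyond the scatter), whereas the earlier exchange of one aromatic ring for another gave only a 1.6-fold higher number from compound 1 to compound 3 (0.21 log units; within the scatter). The 1-acetylpiperidin-4-yl group remains well apart, with a 7.7-fold lower number from compound 2 to compound 4 (0.88 log units; beyond the scatter), so all three aromatic groups shown stand below compound 2, but they now span a measurable range rather than a single level. Nothing shown gives a cause for these differences.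

The step from compound 3 to compound 4 changes ring size, heavy-atom count and the presence of the (dimethylamino)methyl group all at once, and the compounds shown cannot say which of these goes with the higher number. A plain 2-methylpyridin-3-yl would separate the loss of that amine from the change of ring, and a 1,3-dimethyl-1H-pyrazol-4-yl analogue carrying a dimethylaminomethyl chain would test the same question from the other side.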